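A few compounds are considered here, and "the series" means these few. Any claim that something is new, unique, unknown or untested is made for them only; others in the source may bear on it.

Working notes on the series in a functional assay on HCT-15 cells (Homo sapiens) for inhibition, read by sulforhodamine B assay, with a stated time of 48 h; on this read-out lower numbers stand for higher toxicity in this test and higher numbers for lower toxicity in this test.

Compound 1 `COc1cc(C)cc(-c2nn(CC#N)cc2-c2ccc(-c3cccc(C(C)=O)c3)nc2)c1` sits at the assay limit: in this assay compound 1 gives > 100000 nM, which is a limit and not a number. Compound 2 `Cc1cc(O)cc(-c2nn(CC#N)cc2-c2ccnc(-c3ccc(Oc4ccccc4)cc3)c2)c1` carries a hydroxy in place of the methoxy and a phenoxy-substituted aryl on the pyridine; in this assay compound 2 gives 26100 nM. Compound 3 `COc1cc(C)cc(-c2nn(CC#N)cc2-c2ccnc(-c3ccc(N(C)C)cc3)c2)c1` combines the methoxy of compound 1 with a dimethylamino-substituted aryl; in this assay compound 3 also gives only a limit, > 100000 nM. Thus compound 3 stands where two of the three values stand, at the limit of > 100000 nM in this assay, at which 2 of the 3 values shown sit, and no step between two measured compounds is available to size the change.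

Compound 4 `Cc1cc(O)cc(-c2nn(CC#N)cc2-c2ccnc(-c3ccc(N(C)C)cc3)c2)c1` differs from compound 3 by hydrogen in place of methyl on an oxygen on an aromatic ring. Among the compounds shown, the only one bearing the hydroxy, compound 2, is also the only one that gives a number rather than a limit. On that slim basis a shift toward a measurable value is expected, with the step from compound 3 to compound 4 estimated at an at least 1.6-fold lower number from compound 3 to compound 4 (0.22 log units; that floor lies within the scatter). Compound 4 is expected to give about 60000 nM, within 20000 nM to 200000 nM, with a fair chance that only a limit is reported again.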

Compound 4, concentration lethal to 50% of the cells: > 100000 nM
Compound 4 ended at the assay's limit; the forecaster's own chance of this, stated with the estimate: 45%; at least 1.6-fold (0.22 log units) between middle value and limit.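

In this assay compound 4 gives > 100000 nM, which is a limit and not a number, so methoxy to hydroxy on the aromatic ring does not yield a measurable value with the dimethylamino-substituted aryl in place; the step between compound 3 and compound 4, with limits on both sides, cannot be read. Among these compounds, the hydroxy therefore no longer coincides with a number in every case, and with the hydroxy held constant, dimethylamino in place of phenoxy on an aromatic carbon gives an at least 3.8-fold higher number from compound 2 to compound 4 (0.58 log units; beyond the scatter), the first readable step, beyond the usual scatter but open-ended in size. Compound 2 remains the only compound with a number, and the rest of the series stays out of reach of measurement: the limit of > 100000 nM in this assay, at which 3 of the 4 values shown sit.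

On these data alone, what methoxy in place of hydroxy does with the phenoxy group present stays open, and so does the true size of any step that ends at a limit. Also open, as far as these compounds go, is how a carboxylic acid or a morpholine in place of phenoxy on that aryl would read in this assay.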